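Two Fluorine Steps in One Cytotoxicity Series

A few compounds are considered here, and "the series" means these few. Any claim that something is new, unique, unknown or untested is made for them only; others in the source may bear on it.

The measured compounds and their values:
compound 1 `O=C1/C(=C/c2ccccc2)CCC/C1=C\c1ccccc1[N+](=O)[O-]` gives 3800 nM
compound 2 `O=C1/C(=C/c2ccc(F)cc2)CCC/C1=C\c1ccccc1[N+](=O)[O-]` gives 2700 nM
compound 3 `O=C1/C(=C/c2ccccc2)CCC/C1=C\c1ccc([N+](=O)[O-])cc1` gives 4900 nM

All three were tested in a functional assay on HSC-2 cells (Homo sapiens) for cytotoxicity, with a stated time of 24 h; a lower number here means that less compound is tolerated, a higher number that more compound is tolerated. Compound 2 differs from compound 1 by a single change, (fluoro in place of hydrogen on an aromatic carbon), and this change gave a 1.4-fold lower number from compound 1 to compound 2 (0.15 log units; within the scatter), a step that stays within the scatter of the method. Compound 3 carries the same atoms as compound 1 joined differently; the difference between the two cores is not broken down here. In this assay compound 3 and compound 1 lie within the scatter of each other, as do compound 3 and compound 2, so no order among the three can be read from these numbers.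

Compound 4 `O=C1/C(=C/c2ccc(F)cc2)CCC/C1=C\c1ccc([N+](=O)[O-])cc1` has not yet been measured. It stands to compound 3 as compound 2 stands to compound 1: the change is fluoro in place of hydrogen on an aromatic carbon, and the place of the change reads the same in both cases, so it is the same change on a different core. For the measured compounds named here, with only one earlier example to go on, the step from compound 3 to compound 4 is expected to be about as small as the one from compound 1 to compound 2, that is a 1.4-fold lower number from compound 3 to compound 4 (0.15 log units; within the scatter), because compound 1 to compound 2 gave a 1.4-fold lower number from compound 1 to compound 2 (0.15 log units; within the scatter). On this basis compound 4 is estimated to give 3500 nM in this assay, with a likely range from 1800 nM to 7000 nM.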

Compound 4, half-maximal cytotoxic concentration: 19000 nM
For compound 4 the middle estimate is 5.4-fold (0.73 log units) below the measured one; the measured number lies above the stated range.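

In this assay the fluoro group did not behave on the core of compound 3 as it had on the core of compound 1: replacing phenyl with 4-fluorophenyl gave a 3.9-fold higher number from compound 3 to compound 4 (0.59 log units; beyond the scatter), a modest step, whereas the earlier step, a 1.4-fold lower number from compound 1 to compound 2 (0.15 log units; within the scatter), stayed within the scatter. The two steps differ by more than the method's scatter can account for, so in this series the result of this change cannot simply be carried from one of these cores to the other: the same change on two cores in this assay, a 1.4-fold lower number (0.15 log units; within the scatter) from compound 1 to compound 2 and a 3.9-fold higher number (0.59 log units; beyond the scatter) from compound 3 to compound 4, 5.5-fold (0.74 log units) apart, beyond the scatter of two such steps. For the compounds shown here, this does not show why the two cores part ways or establish a general rule for the change, since each core supplies only one pair of compounds and the pairs come from a single cell line and a single read-out.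

The compounds shown leave open whether the rise on the core of compound 3 is particular to fluoro or would also appear with chloro, methoxy or an amine in the same place on the ring. They also leave open how the same change would read on a core bearing a carboxylic acid or a nitrile where compound 3 carries its nitro group.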